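Indazole acids: oxazole in place of thiazole

The compounds below may be only part of what the source reports. "The series", "measured", "known", "first", "only" and "open" are said of these compounds alone.

Measured compounds:
compound 1, `CNc1ccc2[nH]nc(C(=O)O)c2c1`, > 30000 nM
compound 2, `Cc1nc(-c2cccc(CNc3ccc4[nH]nc(C(=O)O)c4c3)c2O)sc1C`, 25 nM

Two compounds carry numbers in an assay on isolated protein for inhibition of 2-Hydroxyacid oxidase 1 (Homo sapiens), with stated times of 30 min and 15 min; a higher number here means a weaker inhibitor, a lower number a stronger inhibitor. For compound 1, the result is a limit of the assay rather than a number: compound 1 gives > 30000 nM, and the limit of > 30000 nM in this assay, at which 1 of the 2 values shown sits, records that one of the two values sits at that limit. Compound 2 gives 25 nM, the only proper number shown, so compound 2 stands alone as the reference point for what follows.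

Compound 3, `CC(C)c1coc(-c2cccc(CNc3ccc4[nH]nc(C(=O)O)c4c3)c2O)n1`, has not yet been measured in this assay. Its structure differs from compound 2 in one place: 4-isopropyl-1,3-oxazol-2-yl in place of 4,5-dimethyl-1,3-thiazol-2-yl on an aromatic carbon. Among the measured compounds shown here, the group that leaves and the group that enters are both five-membered aromatic rings with two hetero atoms and the same count of hydrogen-bond acceptors, and no measured step of this kind is available to guide the size of the change.

Compound 3 is therefore expected to stay close to compound 2, with a step from compound 2 to compound 3 of a 1.6-fold higher number from compound 2 to compound 3 (0.20 log units; within the scatter), which is expected to lie near the usual scatter. The estimate for compound 3 in this assay is 40 nM, with an expected range from 10 nM to 160 nM.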

Compound 3, half-maximal inhibitory concentration in the 2-Hydroxyacid oxidase 1 assay: 87 nM
The estimate for compound 3 lay 2.2-fold (0.34 log units) below the measured number; the measured number falls inside the stated range.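

In the 2-Hydroxyacid oxidase 1 assay, placing 4-isopropyl-1,3-oxazol-2-yl where 4,5-dimethyl-1,3-thiazol-2-yl stood, on the aromatic carbon ortho to a hydroxy group, gives a 3.5-fold higher number from compound 2 to compound 3 (0.54 log units; beyond the scatter), so this position distinguishes between two groups that each hold one five-membered aromatic ring with 2 hetero atoms and 2 hydrogen-bond acceptors. The same pair also differs in a physicochemical assay for solubility, measured as kinetic solubility, at pH 2 (a higher number here means a more soluble compound, a lower number a less soluble compound), where compound 2 gives 20000 nM and compound 3 gives 4000 nM, a 5.0-fold lower number from compound 2 to compound 3 (0.70 log units; beyond the scatter). Set side by side, compound 3 has the higher number in the 2-Hydroxyacid oxidase 1 assay and the lower number in the physicochemical assay, so it is the less favourable of the pair on both read-outs.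

This one step alters the ring's hetero atom and its alkyl groups together, so the compounds shown cannot tell which of these accounts for either difference. From the compounds shown here alone, a 4,5-dimethyl-1,3-oxazol-2-yl or a 4-isopropyl-1,3-thiazol-2-yl group at this position would pull the two apart, and how a ring bearing an amine would read remains open as well.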